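This account rests on a few compounds, and the source may have more. Where it says the series, first, only, none or still open, it means among the compounds named here.

Of the compounds shown here, three have been measured in a functional assay on Huh-7 cells (Homo sapiens) for antiproliferative activity, read by CCK-8 assay, with a stated time of 72 h; on this read-out higher numbers stand for weaker inhibition of growth and lower numbers for stronger inhibition of growth. Compound 1 `CCC1C(=O)N(C)c2cnc(Nc3ccc(S(=O)(=O)NC)cc3)nc2N1c1ccn(C)n1` gives 11900 nM in this assay. Compound 2 `CCCNS(=O)(=O)c1ccc(Nc2ncc3c(n2)N(c2ccn(C)n2)C(CC)C(=O)N3C)cc1` gives 8880 nM, and compound 3 `CCCCNC(=O)c1ccc2c(ccn2-c2ncc3c(n2)N(c2ccn(C)n2)C(CC)C(=O)N3C)c1` gives 8670 nM. All three numbers sit close together, and none of them can be set apart from the others.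

Compound 1 and compound 2 differ by hydrogen in place of ethyl on a saturated chain carbon bound to a sulfonamide nitrogen. Measured in this assay, that change reads a 1.3-fold higher number from compound 2 to compound 1 (0.13 log units; within the scatter). The difference between the core of compound 2 and the core of compound 3 is not broken down here.

Compound 4 `CCNC(=O)c1ccc2c(ccn2-c2ncc3c(n2)N(c2ccn(C)n2)C(CC)C(=O)N3C)c1` has not yet been measured. It differs from compound 3 by hydrogen in place of ethyl on a saturated chain carbon, two bonds along the chain from an amide-type nitrogen. Within the data shown here, this is the same kind of change as the one between compound 2 and compound 1, though not at the same place: in the earlier pair the carbon is bound to a sulfonamide nitrogen, whereas in compound 4 it lies two bonds along the chain from an amide-type nitrogen. The expectation rests on the earlier step, which lay within the scatter. The step from compound 3 to compound 4 is therefore expected to be small, a 1.2-fold higher number from compound 3 to compound 4 (0.06 log units; within the scatter). Compound 4 is estimated at 10000 nM, with a likely range from 5000 nM to 20000 nM.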

Compound 4, concentration for 50% growth inhibition: 20300 nM
Compound 4: middle estimate off by 2.0-fold (0.31 log units), on the low side, and the stated range ends below it.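

On the core of compound 3, hydrogen in place of ethyl, two bonds along the chain from an amide-type nitrogen, gives in this assay a 2.3-fold higher number from compound 3 to compound 4 (0.37 log units; beyond the scatter), a modest step that stands clear of the usual scatter. Set beside the same change on the other core, the two steps cannot be told apart: the same change on two cores in this assay, a 1.3-fold higher number (0.13 log units; within the scatter) from compound 2 to compound 1 and a 2.3-fold higher number (0.37 log units; beyond the scatter) from compound 3 to compound 4, 1.7-fold (0.24 log units) apart, within the scatter of two such steps. Among these compounds, this shows that the result on one core is compatible with the result on the other, but only the step on the core of compound 3 can be read as a real loss of growth inhibition; it does not show that the change has the same effect on both cores, and two pairs cannot establish a rule for the series.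

The compounds shown leave open how a longer chain, an amine or a carboxylic acid in place of the butyl group of compound 3 would read. They also leave open whether the same change would give a step beyond the scatter on the core of compound 2.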